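Bromo Steps on a Shared Core in Cell Cytotoxicity

A few compounds are considered here, and "the series" means these few. Any claim that something is new, unique, unknown or untested is made for them only; others in the source may bear on it.

Compound 1 `COC1=C(Br)C(=O)[C@]2(C=C1)CO2`: 11000 nM
Compound 2 `COC1=CC(=O)[C@]2(C=C1)CO2`: 33000 nM
Compound 3 `O=C1C=CC(Br)=C[C@]12CO2`: a limit only, > 25000 nM

In an ADME assay on BAEC cells (Bos taurus) for cytotoxicity, read by MTT assay, with a stated time of 2 days (a lower number here means a stronger inhibitor, a higher number a weaker inhibitor), compound 2 gives 33000 nM, while compound 1 gives 11000 nM. The change between them, (bromo in place of hydrogen on a double-bonded ring carbon), gave a 3.0-fold lower number from compound 2 to compound 1 (0.48 log units; beyond the scatter). For compound 3 the assay reports only a limit, > 25000 nM. Its value therefore sits at the limit of > 25000 nM in this assay, at which 1 of the 3 values shown sits. The difference between the cores of compound 2 and compound 3 is not broken down here.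

Compound 4 `O=C1C(Br)=CC(Br)=C[C@]12CO2` has not yet been measured in this assay. It differs from compound 3 by bromo in place of hydrogen on a double-bonded ring carbon. Within the data shown here, this is the same kind of change as the one from compound 2 to compound 1, but not the same: in compound 1 the bromo enters next to the ring atom that bears a methoxy group, whereas in compound 4 it enters two ring bonds from the ring atom that bears a bromo group.

In this assay compound 4 is expected to give about 20000 nM, most likely between 6000 nM and 60000 nM. That would mean an estimated step of an at least 1.2-fold lower number from compound 3 to compound 4 (0.09 log units; that floor lies within the scatter). The expectation rests on the step of a 3.0-fold lower number from compound 2 to compound 1 (0.48 log units; beyond the scatter), and on compound 3 having given only a limit, > 25000 nM, so that a reported number for compound 4 is itself uncertain.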

Compound 4, half-maximal inhibitory concentration: 12000 nM
For compound 4 the middle estimate is 1.7-fold (0.22 log units) above the measured one; measured number inside the range.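

On the second core, bromo in place of hydrogen on a double-bonded ring carbon gives an at least 2.0-fold lower number from compound 3 to compound 4 (0.31 log units; beyond the scatter) in this assay, so the lower number seen with this change on the first core appears again, and the step lies beyond the scatter on both cores. For compound 3, however, this assay reports only a limit, > 25000 nM and not a number, so the second step has a floor but no exact size. The two steps therefore show that the direction of the change carries over between these two cores, but they do not show that its size does: the same change on two cores in this assay, a 3.0-fold lower number (0.48 log units; beyond the scatter) from compound 2 to compound 1 and an at least 2.0-fold lower number (0.31 log units; beyond the scatter) from compound 3 to compound 4; the limit leaves it open whether they differ.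

The compounds shown leave open whether an amine or a carboxylic acid on the same double-bonded ring carbon would go with a similar shift in this assay. They also leave open how a longer chain in place of the methoxy group would behave, and whether the bromo step would hold on such a core.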